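Mouse microsomal clearance: pyrimidin-2-yl in place of isopropyl

The compounds below may be only part of what the source reports. "The series", "measured", "known", "first", "only" and "open" are said of these compounds alone.

Measured so far in an in vitro ADME assay on microsomes from liver (Mus musculus) for pharmacokinetics, read by LC-MS, with a stated time of 10 min, tested at 1 uM; a lower number here means slower removal, a higher number faster removal of the compound
- compound 1 `CC(C)c1ccc(NC(=O)[C@H]2CN(C)C[C@@H]2c2ccc(/C=C/C(=O)Nc3ccccc3N)cc2)cc1` gives 54 mL/min/kg
- compound 2 `CC(C)N1C[C@H](C(=O)Nc2ccc(Cl)cc2)[C@@H](c2ccc(/C=C/C(=O)Nc3ccccc3N)cc2)C1` gives 38 mL/min/kg

Only these two compounds have been measured, and their values lie within the usual scatter of each other. On these numbers, compound 2 (38 mL/min/kg) therefore cannot be separated from compound 1 (54 mL/min/kg) in this assay.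

The next compound to be measured is compound 3 `Nc1ccccc1NC(=O)/C=C/c1ccc([C@H]2CN(c3ncccn3)C[C@@H]2C(=O)Nc2ccc(Cl)cc2)cc1`. It differs from compound 2 by the change (pyrimidin-2-yl in place of isopropyl on an amine nitrogen in a ring), with pyrimidin-2-yl in place of isopropyl on an amine nitrogen in a ring. For the measured compounds named here, the series has no measured pair that differs in one place only, so no direct precedent exists for this change. The expectation therefore starts from compound 2 (38 mL/min/kg) and carries a wide range.

No step beyond the scatter is expected in this assay, and neither direction is favoured. The expected move is a 1.1-fold higher number from compound 2 to compound 3 (0.04 log units; within the scatter), which would leave the two compounds within the scatter of each other. The estimate for compound 3 is 42 mL/min/kg (expected range 20 mL/min/kg to 85 mL/min/kg).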

Compound 3, clearance: 44 mL/min/kg
Compound 3: middle estimate off by 1.0-fold (0.02 log units), on the low side; measured number inside the range.
By their numbers in this assay, from the lowest: compounds 2, 3 and 1 (each within the scatter of the next).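

In this assay, the series now has its first pair that differs in one place, and it gives a 1.2-fold higher number from compound 2 to compound 3 (0.06 log units; within the scatter) for pyrimidin-2-yl in place of isopropyl on an amine nitrogen in a ring. For the compounds shown here, with the (4-chlorophenyl)carbamoyl group unchanged, this position takes a six-membered aromatic ring with 2 hetero atoms, and 6 heavy atoms in place of 3, with no step that can be told from the scatter in this read-out. No measurement shown gives a reason for this result or a property of either group.

Still open, going by these compounds, is whether a different group on this nitrogen, such as acetyl, a phenyl ring without hetero atoms or a chain ending in a carboxylic acid, would give a step beyond the scatter. Compound 1 differs from compound 2 in more than one place, so the methyl on this nitrogen cannot be read on its own against isopropyl or pyrimidin-2-yl, and the result for pyrimidin-2-yl is tied to the (4-chlorophenyl)carbamoyl setting of compound 2 and compound 3.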